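A few compounds are considered here, and "the series" means these few. Any claim that something is new, unique, unknown or untested is made for them only; others in the source may bear on it.

Measured so far in the series:
compound 1 `CC(C)=CCc1cc(C(=O)Nc2cc3ccc(OCC4CCCN(C)C4)c(C)c3oc2=O)ccc1O` — 1300 nM
compound 2 `CCN(CC)CCCOc1ccc2cc(NC(=O)c3ccc(O)c(CC=C(C)C)c3)c(=O)oc2c1C` — 4900 nM
compound 3 `CC(C)=CCc1cc(C(=O)Nc2cc3ccc(OCCCNc4ccccc4)c(C)c3oc2=O)ccc1O` — > 50000 nM

In a functional assay on SK-BR-3 cells (Homo sapiens) for antiproliferative activity (a higher number here means a weaker inhibitor, a lower number a stronger inhibitor), compound 1 gives 1300 nM and compound 2 gives 4900 nM. For compound 3 the assay returns only a limit, > 50000 nM, which is the limit of > 50000 nM in this assay, at which 1 of the 3 values shown sits. Compound 2 thus carries the higher of the two numbers; the step of a 3.8-fold higher number from compound 1 to compound 2 (0.58 log units; beyond the scatter) separates it from compound 1. Compound 3 sits further out still: an at least 38-fold higher number from compound 1 to compound 3 (1.58 log units; beyond the scatter) and an at least 10-fold higher number from compound 2 to compound 3 (1.00 log units; beyond the scatter).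

Compound 4 `CC(C)=CCc1cc(C(=O)Nc2cc3ccc(OCCCNC(C)(C)c4ccccc4)c(C)c3oc2=O)ccc1O` has not yet been measured in this assay. Against compound 2 the change is (1-methyl-1-phenylethyl)amino in place of diethylamino on a saturated chain carbon, three bonds along the chain from an oxygen on an aromatic ring. Within the data shown here, the one measured step that bears on it is an at least 10-fold higher number from compound 2 to compound 3 (1.00 log units; beyond the scatter), where anilino replaced diethylamino on the same chain carbon and the number rose to the limit. Compound 4 carries a (1-methyl-1-phenylethyl)amino group with one hydrogen-bond donor rather than the anilino of compound 3, so a rise smaller than that step is expected, though still beyond the scatter. The expected step is a 2.4-fold higher number from compound 2 to compound 4 (0.39 log units; beyond the scatter). Compound 4 is accordingly estimated at 12000 nM, with a range from 4000 nM to 50000 nM, and some chance that only a limit is returned.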

Compound 4, half-maximal inhibitory concentration: 960 nM
Compound 4: middle estimate off by 13-fold (1.10 log units), on the high side; the whole stated range lies above it.
By their numbers in this assay, from the lowest: compounds 4 and 1 (each within the scatter of the next); then compound 2. At a limit, above all of these: compound 3.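

At the saturated chain carbon three bonds along the chain from the oxygen on the aromatic ring, (1-methyl-1-phenylethyl)amino, with its six-membered aromatic ring and hydrogen-bond donor, is tolerated in this assay and improves on diethylamino: a 5.1-fold lower number from compound 2 to compound 4 (0.71 log units; beyond the scatter). On the amine nitrogen, 1-methyl-1-phenylethyl in place of phenyl gives an at least 52-fold lower number from compound 3 to compound 4 (1.71 log units; beyond the scatter), so the loss seen with compound 3 does not extend to every amine here that carries such a ring, and the size of this step is bounded by a limit: the limit of > 50000 nM in this assay, at which 1 of the 4 values shown sits. The open-chain amine of compound 4 also matches the 1-methylpiperidin-3-yl compound, with a 1.4-fold lower number from compound 1 to compound 4 (0.13 log units; within the scatter), so the ring of compound 1 is not needed to reach that level in this assay.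

The compounds shown do not separate the part played by the two methyl groups from that of the phenyl ring, which benzylamino and tert-butylamino groups at the same chain carbon would address. They also leave open whether the amine hydrogen matters, a question for an N-methyl tertiary amine, and how a longer chain would behave with this amine.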